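Fluoro removal on the sulfonyl phenyl of compound 2

This account rests on a few compounds, and the source may have more. Where it says the series, first, only, none or still open, it means among the compounds named here.

Working notes on the series. Two compounds carry numbers in a functional assay on A2780 cells (Homo sapiens) for inhibition, read by sulforhodamine B assay, with a stated time of 72 h; on this read-out higher numbers stand for weaker inhibition and lower numbers for stronger inhibition. Compound 1 (`O=C(NCc1ccc(S(=O)(=O)c2ccccc2)cc1)c1cnc2nccn2c1`) gives 68 nM in this assay. Compound 2 (`O=C(NCc1ccc(S(=O)(=O)c2cccc(F)c2)cc1)c1cc2cnccc2[nH]1`) gives 11 nM in this assay, the lowest of the two numbers shown; its nearest neighbour, compound 1, lies clearly higher, beyond the scatter. Among the measured compounds shown here, the two differ both in the core and on the sulfonyl phenyl, so the pair shows only its two values and no single-point step.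

Compound 3 (`O=C(NCc1ccc(S(=O)(=O)c2ccccc2)cc1)c1cc2cnccc2[nH]1`) has not been measured. It differs from compound 2 in one place: hydrogen in place of fluoro on an aromatic carbon. For the measured compounds named here, no measured pair in the set carries exactly this change, so the expected step has no direct anchor in this assay. Loss of one fluorine is a small edit, and the expectation is a step of modest size, if any, toward a somewhat higher number. Compound 3 is expected to give about 18 nM, with a range from 7 nM to 45 nM. The step that this estimate means, a 1.6-fold higher number from compound 2 to compound 3 (0.21 log units; within the scatter), is expected to lie within the scatter.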

Compound 3, half-maximal inhibitory concentration: 18 nM
Estimate against measurement, compound 3: no gap at the digits printed; measured number inside the range.
By their numbers in this assay, from the lowest: compounds 2 and 3 (each within the scatter of the next); then compound 1.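

In this assay the change from 3-fluorophenyl to phenyl gives a 1.6-fold higher number from compound 2 to compound 3 (0.21 log units; within the scatter) and so stays within the scatter, which means this assay does not tell fluoro from hydrogen on this aromatic carbon. The change can now be read on its own, which the first two compounds did not allow, since they differed in two places. With the phenyl held constant, exchange of the core gives a 3.8-fold lower number from compound 1 to compound 3 (0.58 log units; beyond the scatter) in this assay and lies beyond the scatter, so of the two single-place changes now readable, only the core change has a size that stands clear of repeat variation. No measurement in hand gives a reason for either step.

Only hydrogen and fluoro are shown on this carbon, so it stays open whether a larger or differently charged group there, such as methoxy, trifluoromethyl or an amine, would leave the number in this assay as little moved. On these data alone, it also stays open whether the core step keeps its size with a 3-fluorophenyl in place of the phenyl on the sulfonyl group.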